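Chloro to methyl on the shared core of compound 2

The compounds below may be only part of what the source reports. "The series", "measured", "known", "first", "only" and "open" are said of these compounds alone.

Measured in an assay on mitochondria (strain Sprague-Dawley) for inhibition of Amine oxidase [flavin-containing] B (Rattus norvegicus), read by fluorescence and Amplex Red, with stated times of 30 min and 45 min; a higher number here means a weaker inhibitor, a lower number a stronger inhibitor:
- compound 1, `COc1cccc(CCC(=O)Nc2nc3ccccc3c(=O)s2)c1`: 621 nM
- compound 2, `O=C(CCCc1ccccc1)Nc1nc2ccc(Cl)cc2c(=O)s1`: > 10000 nM
- compound 3, `O=C(CCCc1ccccc1)Nc1nc2sccc2c(=O)s1`: 291 nM
- compound 4, `Cc1ccc2nc(NC(=O)CCCc3ccccc3)sc(=O)c2c1`: not yet measured

Compound 2 stands at the edge of the series: its value in this assay is only a limit of the assay, not a number (the limit of > 10000 nM in this assay, at which 1 of the 3 values shown sits). Compound 1 and compound 3 both return numbers. Compound 4 differs from compound 2 by methyl in place of chloro on an aromatic carbon. Among the compounds with values here, no measured pair isolates this change, so its effect cannot be read from the series. The step from compound 2 to compound 4 is expected to run toward a stronger inhibitor, about an at least 3.3-fold lower number from compound 2 to compound 4 (0.52 log units; beyond the scatter), though a second limit would not surprise. Compound 4 is estimated at 3000 nM, in a range from 700 nM to 12000 nM.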

Compound 4, half-maximal inhibitory concentration: 325 nM
Beside the measured number, compound 4's estimate is 9.2-fold (0.97 log units) above it; measured number outside the range, below it.
By their numbers in this assay, from the lowest: compounds 3, 4 and 1 (each within the scatter of the next, the first and the last beyond it). At a limit, above all of these: compound 2.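

In this assay, within the data shown here, methyl in place of chloro on this aromatic carbon gives an at least 30-fold lower number from compound 2 to compound 4 (1.48 log units; beyond the scatter), the only step that reads this position. A substituent on this carbon is therefore compatible with a measurable value, as compound 4 shows at 325 nM, so the loss seen with chloro does not extend to every group here. Compound 2 gives a limit, not a number: the limit of > 10000 nM in this assay, at which 1 of the 4 values shown sits.

On these data alone, with a single pair, the trend at this position remains open. Whether fluoro, a nitrile or an amine on this carbon would track with methyl or with chloro is unresolved.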